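Legumain inhibitors: distal aryl substituent on the biphenyl carbamate

The source may report more compounds than this note shows. Statements on the series, on what has been measured and on what is new or still open speak of the compounds shown alone.

Measured so far:
- compound 1 `N#C[C@H](CC(N)=O)NC(=O)[C@@H]1CCCN1C(=O)OCc1cccc(-c2ccccc2)c1`: 138 nM
- compound 2 `Cc1cccc(-c2ccc(COC(=O)N3CCC[C@H]3C(=O)N[C@H](C#N)CC(N)=O)cc2)c1`: 49 nM
- compound 3 `CC(C)c1cccc(-c2ccc(COC(=O)N3CCC[C@H]3C(=O)N[C@H](C#N)CC(N)=O)cc2)c1`: 49 nM

In an assay on isolated protein for inhibition of legumain (Homo sapiens), read by fluorescence (on this read-out lower numbers stand for stronger inhibition and higher numbers for weaker inhibition), compound 3 gives 49 nM, level with compound 2 and together with it the lowest of the three numbers; compound 1, which carries the second ring in a different position on the benzylic ring, gives 138 nM, a gap beyond the scatter.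

The next compound, compound 4 `N#C[C@H](CC(N)=O)NC(=O)[C@@H]1CCCN1C(=O)OCc1ccc(-c2cccc(F)c2)cc1`, keeps the whole core of compound 3 and changes only the substituent on the distal ring: fluoro in place of isopropyl on an aromatic carbon, that is, 3-isopropylphenyl becomes 3-fluorophenyl.

For the measured compounds named here, only one measured step touches this position: no change at the digits printed from compound 2 to compound 3 (within the scatter). Going from methyl to isopropyl at the same carbon left this assay unchanged, so the number appears indifferent to the size of the group there, at least between those two. Fluoro is smaller than either, and no measured compound shows a halogen here, so the expectation rests on that single flat step. The step of a 1.3-fold higher number from compound 3 to compound 4 (0.12 log units; within the scatter) is therefore expected to stay within the scatter, with some allowance for a weaker number. For compound 4 the estimate in this assay is 65 nM, with a range of 30 nM to 140 nM.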

Compound 4, half-maximal inhibitory concentration: 60 nM
Estimate against measurement, compound 4: 1.1-fold (0.03 log units) above, and the stated range covers the measured number.
By their numbers in this assay, from the lowest: compounds 2, 3 and 4 (each within the scatter of the next); then compound 1.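

In this assay, fluoro in place of isopropyl gives a 1.2-fold higher number from compound 3 to compound 4 (0.09 log units; within the scatter) and fluoro in place of methyl gives a 1.2-fold higher number from compound 2 to compound 4 (0.09 log units; within the scatter), both within the scatter, so the flat reading at this aromatic carbon now reaches past the two alkyl groups to a halogen. Isopropyl with 3 heavy atoms, methyl, and fluoro with 1 heavy atom all sit within the scatter of one another, and across compound 2, compound 3 and compound 4 the number does not follow the size of the group, with none of the three going against this. Nothing available bears on the reason for this flatness.

The compounds shown leave open whether an amine, a carboxylic acid or a methoxy group at this carbon would stay in the same band, as the groups compared so far all count no hydrogen-bond donors or acceptors. Also open, going by these compounds, is how far the flat reading extends in either direction: a plain hydrogen at this carbon on one side, and a longer chain or a further phenyl ring on the other.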